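Swapping the substituted phenyl of compound 3

The compounds below may be only part of what the source reports. "The series", "measured", "known", "first", "only" and "open" are said of these compounds alone.

In an ADME assay on the whole organism (Rattus norvegicus) for pharmacokinetics, using cassette dosing, at a dose of 1 mg/kg by the oral route (a lower number here means that a smaller share of the oral dose reaches the circulation, a higher number that a larger share of the oral dose reaches the circulation), compound 1 `Cc1cc(/N=c2\[nH]c(=O)n(C[C@H](C)C(=O)O)c(=O)n2Cc2ccc(Cl)cc2)ccc1OC(C)C` reaches 102% as its reading. Compound 3 `CC(C)Oc1ccc(/N=c2\[nH]c(=O)n(C[C@H](C)C(=O)O)c(=O)n2Cc2ccc(Cl)cc2)cc1Cl` stands at 82.4% clearly short of compound 1 and within the usual scatter of compound 2 `C[C@@H](Cn1c(=O)[nH]/c(=N\c2ccc(Oc3cncc(F)c3)cc2)n(Cc2ccc(Cl)cc2)c1=O)C(=O)O` with its 74.3% reading. The change to compound 4 `C[C@@H](Cn1c(=O)[nH]/c(=N\c2ccc(OC3CCC3)cc2)n(Cc2ccc(Cl)cc2)c1=O)C(=O)O` is this: 4-(cyclobutyloxy)phenyl in place of 3-chloro-4-isopropoxyphenyl on a double-bonded nitrogen while the shared core stays. Among the compounds with values here, only one measured step bears on it: a number 19.6 percentage points lower from compound 1 to compound 3 (beyond the scatter) for chloro in place of methyl on an aromatic carbon. That modest step says nothing about a cyclobutyloxy group, so no direction can be argued and no step beyond the scatter is expected in this assay here. The expected step is a number 2.4 percentage points lower from compound 3 to compound 4 (within the scatter) at the middle of the estimate. Compound 4 is expected at 80% within a range of 55% to 105% in this estimate.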

Compound 4, oral bioavailability: 54.3%
Compound 4: the middle estimate sits 25.7 percentage points above what was measured; the whole stated range lies above it.
By their numbers in this assay, from the lowest: compound 4; then compounds 2 and 3 (each within the scatter of the next); then compound 1.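

In this assay, the group on the double-bonded nitrogen can move the reading well beyond the scatter with no change in heavy-atom count: 4-(cyclobutyloxy)phenyl gives a number 28.1 percentage points lower from compound 3 to compound 4 (beyond the scatter) and a number 47.7 percentage points lower from compound 1 to compound 4 (beyond the scatter). On the oxygen on the aromatic ring, cyclobutyl in place of 5-fluoropyridin-3-yl likewise gives a number 20 percentage points lower from compound 2 to compound 4 (beyond the scatter). No measurement at hand explains these drops. From the compounds shown here alone, whether they belong to the cyclobutyl ring or to the loss of the chloro or methyl group stays open. So does how a cyclopentyl ring or a longer alkyl chain on that oxygen would read.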